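Swapping a methoxy for a bromo and fluoro pair

The source may hold more compounds than are shown below. What is called first, only, known or untested is meant among the compounds shown, and "the series" means these compounds.

Three compounds sharing one core were tested in a functional assay on MCF7 cells (Homo sapiens) for inhibition, read by MTT assay; on this read-out lower numbers stand for stronger inhibition and higher numbers for weaker inhibition. Compound 1 `COc1cc2ncnc(Nc3ccc(NC(=O)c4ccccc4C)cc3)c2cc1OC` gives 21000 nM. Compound 3 `COc1cc2ncnc(Nc3ccc(NC(=O)c4ccccc4I)cc3)c2cc1OC` gives 37000 nM. Compound 2 `COc1cc2ncnc(Nc3ccc(NC(=O)c4ccccc4OC)cc3)c2cc1OC` yields only a limit in this assay, > 100000 nM, so its true number is not known. Its standing can be read only from the steps: an at least 4.7-fold higher number from compound 1 to compound 2 (0.67 log units; beyond the scatter), and an at least 2.7-fold lower number from compound 2 to compound 3 (0.43 log units; beyond the scatter). Between compound 1 and compound 3 the change is a 1.8-fold higher number from compound 1 to compound 3 (0.25 log units; within the scatter).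

On these data alone, compound 4 `COc1cc2ncnc(Nc3ccc(NC(=O)c4cc(F)ccc4Br)cc3)c2cc1OC` is untested. It differs from compound 2 by 2-bromo-5-fluorophenyl in place of 2-methoxyphenyl on a carbonyl carbon. For the measured compounds named here, the step that bears on it most is the one from compound 2 to compound 3, where iodo in place of methoxy lowered the number past the scatter; the step from compound 1 to compound 2 also shows methoxy going with the highest number. Compound 4 is therefore expected to give a lower number than the limit of compound 2, with an estimated step of an at least 2.8-fold lower number from compound 2 to compound 4 (0.45 log units; beyond the scatter). The estimate for compound 4 is 35000 nM, between 10000 nM and 120000 nM.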

Compound 4, half-maximal inhibitory concentration: 26000 nM
Beside the measured number, compound 4's estimate is 1.3-fold (0.13 log units) above it, within the range that was stated.
By their numbers in this assay, from the lowest: compounds 1, 4 and 3 (each within the scatter of the next). At a limit, above all of these: compound 2.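

In this assay, for the compounds shown here, the 2-bromo-5-fluorophenyl group is the first ring in this set to carry two halogens, and it also gives a clearly lower number than the 2-methoxyphenyl group, with an at least 3.8-fold lower number from compound 2 to compound 4 (0.58 log units; beyond the scatter). Compound 4 cannot be separated from the compounds carrying a single iodo or methyl group, with a 1.4-fold lower number from compound 3 to compound 4 (0.15 log units; within the scatter) and a 1.2-fold higher number from compound 1 to compound 4 (0.09 log units; within the scatter), so a second group on this ring brings no change that can be read here. Compound 2 remains the only compound that stands apart, and its value is a limit: the limit of > 100000 nM in this assay, at which 1 of the 4 values shown sits.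

On these data alone, whether the high number of compound 2 extends to other oxygen groups, such as hydroxy or ethoxy, remains open, as does whether a ring bearing an amine or a carboxylic acid would lower the number past the scatter. The separate contributions of bromo and fluoro are also unresolved, and a 2-bromophenyl group would help to separate them.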